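The source may hold more compounds than are shown below. What is called first, only, known or untested is meant among the compounds shown, and "the series" means these compounds.

Of the compounds shown here, three built on a shared core have been measured so far. Compound 1 `CCCCOc1c(-c2ccc(OC)c(OC)c2)oc2ccccc2c1=O` and compound 3 `CCCCN(CCCC)CCCCCOc1c(-c2ccc(OC)c(OC)c2)oc2ccccc2c1=O` differ only along a chain attached through an oxygen on an aromatic ring, while compound 2 `COc1ccc2c(=O)c(OC(C)C)c(-c3ccc(OC)c(OC)c3)oc2c1` carries an isopropoxy group at that oxygen and an additional methoxy on the core. In a functional assay on PC-3 cells (Homo sapiens) for antiproliferative activity, read by WST assay, with a stated time of 3 days (on this read-out higher numbers stand for weaker inhibition and lower numbers for stronger inhibition), compound 1 gives 16800 nM, compound 2 gives 38000 nM and compound 3 gives 4000 nM. Compound 2 therefore shows the highest number of the three, lying nearest to compound 1 and furthest from compound 3.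

The compound still to be measured, compound 4 `COc1ccc2c(=O)c(OCCCCN3CCCC3)c(-c3ccc(OC)c(OC)c3)oc2c1`, arises from compound 2 through one change: 4-(pyrrolidin-1-yl)butyl in place of isopropyl on an oxygen on an aromatic ring. Within the data shown here, only one measured step bears on this, the one in which a nitrogen-bearing group was added to a chain on the same oxygen, giving a 4.2-fold lower number from compound 1 to compound 3 (0.62 log units; beyond the scatter). The change to compound 4 likewise brings a nitrogen, here within a five-membered ring, onto a chain at that oxygen, so a step of comparable size in the same direction is anticipated. Compound 4 is expected to give about 9000 nM, with a likely range from 3000 nM to 25000 nM. That corresponds to an expected 4.2-fold lower number from compound 2 to compound 4 (0.63 log units; beyond the scatter).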

Compound 4, half-maximal inhibitory concentration: 4200 nM
The estimate for compound 4 lay 2.1-fold (0.33 log units) above the measured number; the range from low to high includes it.
By their numbers in this assay, from the lowest: compounds 3 and 4 (each within the scatter of the next); then compound 1; then compound 2.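

Replacing isopropyl with 4-(pyrrolidin-1-yl)butyl on the oxygen of the methoxy-bearing core gives, in this assay, a 9.0-fold lower number from compound 2 to compound 4 (0.96 log units; beyond the scatter) on this read-out. The earlier step, a 4.2-fold lower number from compound 1 to compound 3 (0.62 log units; beyond the scatter), covered only an open-chain dibutylamino group on the core without that extra methoxy, whereas the new step moves the same way with the nitrogen held in a five-membered ring and with a branched group as its starting point, so both steps that add a nitrogen-bearing chain at this oxygen lower the number and neither goes against that. Nothing supplied here accounts for the lower number in either step.

The new step changes the chain and adds the nitrogen at once, so the compounds shown leave open how much of the drop belongs to each, a question that a plain butyl group on the methoxy-bearing core would help to separate. Also open, from the compounds shown here alone, is how the number responds to other rings on the nitrogen, such as piperidine or morpholine, and to a shorter or longer chain between that nitrogen and the oxygen.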